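Amide versus urea on the shared core: compound 4

This account rests on a few compounds, and the source may have more. Where it says the series, first, only, none or still open, it means among the compounds named here.

Measured in a functional assay on HOP-62 cells (Homo sapiens) for inhibition, read by sulforhodamine B assay, with a stated time of 48 h, tested at 10 uM; on this read-out lower numbers stand for a stronger effect and higher numbers for a weaker effect at the one concentration tested:
compound 1 `COc1cc(Cl)cc(-c2nn(-c3cccc(NC(=O)Nc4cccc(C(F)(F)F)c4)c3)cc2-c2ccncc2)c1`: 15.5%
compound 2 `COc1cc(Cl)cc(-c2nn(-c3cccc(NC(=O)c4cc(C(F)(F)F)cc(C(F)(F)F)c4)c3)cc2-c2ccncc2)c1`: 103%
compound 3 `COc1cc(Cl)cc(-c2nn(-c3cccc(NC(=O)c4ccc(Cl)c(Cl)c4)c3)cc2-c2ccncc2)c1`: 105%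

Compound 2 stands second highest of the three numbers in this assay; its nearest neighbour is compound 3, within the scatter, and compound 1 lies far below it, beyond the scatter. Compound 4 `COc1cc(Cl)cc(-c2nn(-c3cccc(NC(=O)c4cccc(C(F)(F)F)c4)c3)cc2-c2ccncc2)c1` is not yet measured; it differs from compound 2 by hydrogen in place of trifluoromethyl on an aromatic carbon.

Among the compounds with values here, the one measured step, a number 89.5 percentage points higher from compound 1 to compound 3 (beyond the scatter), exchanges the whole group on the carbonyl carbon and does not touch a trifluoromethyl, so no step speaks directly to the change from compound 2 to compound 4. Both amides, compound 2 and compound 3, sit at the weak end of the read-out, and compound 4 remains an amide. The step of a number 3 percentage points lower from compound 2 to compound 4 (within the scatter) is therefore expected to stay within the scatter. Compound 4 is estimated at 100%, with a range from 85% to 115%.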

Compound 4, a percentage reported as activity, at one concentration (the size of the read-out at that concentration, not a potency): 71.6%
Beside the measured number, compound 4's estimate is 28.4 percentage points above it, outside the stated range (below it).
By their numbers in this assay, from the lowest: compound 1; then compound 4; then compounds 2 and 3 (each within the scatter of the next).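

The amides in this assay do not all sit at the weak end: on this aromatic carbon, hydrogen in place of trifluoromethyl gives a large step (a number 31.4 percentage points lower from compound 2 to compound 4 (beyond the scatter)). The group on the carbonyl carbon therefore matters within the amides too (a number 33.4 percentage points lower from compound 3 to compound 4 (beyond the scatter)), although replacing the urea's (3-(trifluoromethyl)phenyl)amino group with 3-(trifluoromethyl)phenyl still costs much of the effect (a number 56.1 percentage points higher from compound 1 to compound 4 (beyond the scatter)). Nothing measured here accounts for these steps.

Open, going by these compounds, is whether an amine or a carboxylic acid on this carbon would shift the read-out further. Also open, on these data alone, is whether the urea would respond to such a change as the amides do.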